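The source may report more compounds than this note shows. Statements on the series, on what has been measured and on what is new or still open speak of the compounds shown alone.

Series notes. Compound 1 `Cn1c(-c2cccnc2)nc2c(NC3CCCC3)ncnc21` carries pyridin-3-yl on the shared core. In a functional assay on CHO cells for antagonist activity at adenosine receptor A2b (Homo sapiens), read by 33P incorporation, with a stated time of 20 min (a lower number here means a stronger inhibitor, a higher number a weaker inhibitor), compound 1 gives a limit, > 30000 nM, not a number. Compound 2 `Cc1cccc(-c2nc3c(NC4CCCC4)ncnc3n2C)c1` carries 3-methylphenyl instead. In this assay, among the compounds with values here, compound 2 gives 6030 nM, the only actual number in hand. The value of compound 1 is a limit (the limit of > 30000 nM in this assay, at which 1 of the 2 values shown sits). The measured step is an at least 4.9-fold lower number from compound 1 to compound 2 (0.69 log units; beyond the scatter). Compound 3 `Cn1c(-c2ccc(Cl)cc2)nc2c(NC3CCCC3)ncnc21` is the next change: 4-chlorophenyl in place of 3-methylphenyl on an aromatic carbon. Within the data shown here, no measured step covers a swap of one carbon-only aryl for another, so no shift beyond the scatter is expected. The expected step is a 1.2-fold lower number from compound 2 to compound 3 (0.08 log units; within the scatter). Compound 3 is estimated at 5000 nM, between 1500 nM and 15000 nM.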

Compound 3, inhibition constant: > 30000 nM
Compound 3: a limit, no number; the forecaster's own chance of this, stated with the estimate: 10%; at least 6.0-fold (0.77 log units) between middle value and limit.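

In this assay, 4-chlorophenyl in place of 3-methylphenyl on this aromatic carbon gives an at least 4.9-fold higher number from compound 2 to compound 3 (0.69 log units; beyond the scatter), so a swap of one carbon-only aryl for another is not neutral at this position. The value of compound 3 is a limit: the limit of > 30000 nM in this assay, at which 2 of the 3 values shown sit. The step from compound 1 to compound 3 cannot be read, and of the three aryl groups shown only the 3-methylphenyl of compound 2 gives an actual number.

As far as these compounds go, how phenyl without a substituent, 4-methylphenyl or 3-chlorophenyl would read stays open. So does whether the identity of the substituent or its ring position carries the step.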